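Ethynyl to Cyano on a Five-Membered Sugar Ring

The source may hold more compounds than are shown below. What is called first, only, known or untested is meant among the compounds shown, and "the series" means these compounds.

Compound 1 `C#C[C@]1(CO)O[C@@H](n2ccc(=O)[nH]c2=O)[C@H](O)[C@@H]1O` gives > 350000 nM in a functional assay on KB cells (Homo sapiens) for cytotoxicity; a lower number here means a stronger inhibitor, a higher number a weaker inhibitor.
Compound 2 `N#C[C@]1(CO)O[C@@H](n2ccc(=O)[nH]c2=O)[C@H](O)[C@@H]1O` gives > 350000 nM in this assay.
Compound 3 `C#C[C@]1(CO)O[C@@H](n2ccc(N)nc2=O)[C@H](O)[C@@H]1O` gives > 350000 nM in this assay.

Each of these three values is a limit of the assay, not a number. The step from compound 1 to compound 2 is a step that the two limits leave unreadable from compound 1 to compound 2; the change is cyano in place of ethynyl on a saturated ring carbon. The difference between the cores of compound 1 and compound 3 is not broken down here.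

Compound 4 `N#C[C@]1(CO)O[C@@H](n2ccc(N)nc2=O)[C@H](O)[C@@H]1O` has not been measured. Among the measured compounds shown here, it differs from compound 3 by cyano in place of ethynyl on a saturated ring carbon, the same change as the one from compound 1 to compound 2, at the same place in the ring.

Because (the limit of > 350000 nM in this assay, at which 3 of the 3 values shown sit), the earlier change gave no readable step, and there is no basis to expect compound 4 to behave differently from compound 3. The step from compound 3 to compound 4 is therefore expected to be a step that the limit leaves unreadable from compound 3 to compound 4. Compound 4 is expected to give about 400000 nM in this assay, most likely again only as a limit.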

Compound 4, half-maximal inhibitory concentration: > 350000 nM
Compound 4: only a limit was reported (the forecaster's own chance of this, stated with the estimate: 90%); the middle value lies beyond the limit too.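

Compound 4 gives > 350000 nM in this assay, which is a limit of the assay and not a number. Compound 3 also sits at a limit, so the size of the step from ethynyl to cyano between compound 3 and compound 4 cannot be read. The compounds shown leave open whether any of them has a measurable effect on these cells, since all their results stand at one limit: the limit of > 350000 nM in this assay, at which 4 of the 4 values shown sit.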